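Amide variation on the shared core: cytotoxicity notes

A few compounds are considered here, and "the series" means these few. Any claim that something is new, unique, unknown or untested is made for them only; others in the source may bear on it.

Measured compounds:
Compound 1 `Cn1ncc([N+](=O)[O-])c1C(=O)Nc1ccc2nc(NC(=O)C3CCCCC3)sc2c1` gives 0.026 ug/mL
Compound 2 `O=C(Nc1ccc2nc(NC(=O)C3CCCCC3)sc2c1)c1cccc(F)c1` gives 0.64 ug/mL
Compound 3 `CCC(C)(C)C(=O)Nc1ccc2nc(NC(=O)C3CCCCC3)sc2c1` gives 1 ug/mL

All numbers come from a functional assay on WI-38 VA13 cells (Homo sapiens) for cytotoxicity; a higher number here means that more compound is needed for the effect, a lower number that less compound is needed. Compound 1 stands lowest of the three: a 25-fold higher number from compound 1 to compound 2 (1.39 log units; beyond the scatter) and a 38-fold higher number from compound 1 to compound 3 (1.59 log units; beyond the scatter), both beyond the scatter. Compound 2 and compound 3 lie close together, since a 1.6-fold higher number from compound 2 to compound 3 (0.19 log units; within the scatter).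

Compound 4 `Cc1coc(C)c1C(=O)Nc1ccc2nc(NC(=O)C3CCCCC3)sc2c1` has not yet been measured in this assay. Its change from compound 1 is 2,4-dimethylfuran-3-yl in place of 1-methyl-4-nitro-1H-pyrazol-5-yl on a carbonyl carbon. The two measured steps that bear on it are the two replacements of the same group on the same carbonyl carbon, from compound 1 to compound 2 and from compound 1 to compound 3, and both were large increases in the number. With a third group taking the same place, a step of similar size and in the same direction is expected, a 23-fold higher number from compound 1 to compound 4 (1.36 log units; beyond the scatter), with the aromatic example of compound 2 taken as the closer guide.

Compound 4 is therefore estimated at 0.6 ug/mL, with a range from 0.15 ug/mL to 2.5 ug/mL.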

Compound 4, half-maximal effective concentration: 2.7 ug/mL
Compound 4: middle estimate off by 4.5-fold (0.65 log units), on the low side, outside the stated range (above it).
By their numbers in this assay, from the lowest: compound 1; then compounds 2 and 3 (each within the scatter of the next); then compound 4.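

In this assay, a five-membered aromatic ring on the carbonyl carbon is not enough to keep the low number of compound 1: 2,4-dimethylfuran-3-yl in place of 1-methyl-4-nitro-1H-pyrazol-5-yl gives a 100-fold higher number from compound 1 to compound 4 (2.02 log units; beyond the scatter). The replacements also differ among themselves, with a 2.7-fold higher number from compound 3 to compound 4 (0.43 log units; beyond the scatter) and a 4.2-fold higher number from compound 2 to compound 4 (0.63 log units; beyond the scatter), so compound 4 stands highest of the set and its aromatic ring does not place it with compound 2. No measured property is available to explain these differences.

Which part of 1-methyl-4-nitro-1H-pyrazol-5-yl goes with the low number stays open: the nitro group and the pyrazole ring leave together in every step here. A 1-methyl-1H-pyrazol-5-yl group without the nitro group, or a nitrophenyl group, would separate the two.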